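The compounds below may be only part of what the source reports. "The series", "measured", "known", "first", "only" and "open" are said of these compounds alone.

Measured in an ADME assay on microsomes from liver (Homo sapiens) for metabolic stability, read by LC-MS, with a stated time of 30 min, tested at 1 uM; on this read-out lower numbers stand for a less stable compound and higher numbers for a more stable compound:
compound 1 `O=C(NCc1ccc(S(=O)(=O)N2CCCCC2)cc1)c1cc2cnccc2s1`: 15%
compound 2 `O=C(NCc1ccc(S(=O)(=O)N2CCCCC2)cc1)c1cnc2nccn2c1`: 64%
compound 3 `O=C(NCc1ccc(S(=O)(=O)N2CCCCC2)cc1)c1ccn2cncc2c1`: 54%

Compound 2 shares the top of this small set: the gap is only a number 10 percentage points lower from compound 2 to compound 3 (within the scatter). The low end lies far off: a number 49 percentage points higher from compound 1 to compound 2 (beyond the scatter), and likewise a number 39 percentage points higher from compound 1 to compound 3 (beyond the scatter). Compound 4 `O=C(NCc1ccc(S(=O)(=O)c2cccc(C(F)(F)F)c2)cc1)c1cnc2nccn2c1` differs from compound 2 in one group: 3-(trifluoromethyl)phenyl in place of piperidin-1-yl on a sulfonyl sulfur. Those two large steps, like the small one, changed a group on a carbonyl carbon, so none shows what a change on the sulfonyl sulfur does. The estimate therefore starts from compound 2 at 64%, with a wide range and no firm direction. The expected result in this assay is a number 4 percentage points lower from compound 2 to compound 4 (within the scatter), and no step beyond the scatter is expected with confidence. For compound 4 the estimated value is 60%, with an expected range of 30% to 85%.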

Compound 4, percent of the compound remaining: 41%
Beside the measured number, compound 4's estimate is 19 percentage points above it; low and high end bracket the measured number.
By their numbers in this assay, from the lowest: compound 1; then compound 4; then compounds 3 and 2 (each within the scatter of the next).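

In this assay the sulfonyl sulfur proves to be a position that counts: with 3-(trifluoromethyl)phenyl in place of piperidin-1-yl there is a number 23 percentage points lower from compound 2 to compound 4 (beyond the scatter) and the step lies beyond the scatter. So the read-out responds to a change at this end of the molecule, and not only to changes on the carbonyl carbon. Nothing available here explains the drop.

As far as these compounds go, whether it follows from the aromatic ring or from the trifluoromethyl group stays open, and plain phenyl on the sulfonyl sulfur would separate the two. Also open, from the compounds shown here alone, is whether the same change would act alike with the carbonyl group of compound 3.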